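Fluorine Added to the Lower of Two Numbers

A few compounds are considered here, and "the series" means these few. Any claim that something is new, unique, unknown or untested is made for them only; others in the source may bear on it.

Of the compounds shown here, two have been measured in a functional assay on U-87MG ATCC cells for antiproliferative activity against U-87 MG (Homo sapiens), read by MTT assay, with a stated time of 72 h; a lower number here means a stronger inhibitor, a higher number a weaker inhibitor. Compound 1, `CNC(=O)c1cc(Oc2ccc(NC(=O)c3cc4cccnc4n(-c4ccccc4F)c3=O)cc2)ccn1`, gives 3360 nM in this assay. Compound 2, `CCCNC(=O)c1cc(Oc2ccc(NC(=O)c3cc4cccnc4n(-c4ccccc4)c3=O)cc2)ccn1`, gives 1510 nM in this assay, the lower of the two numbers, and the distance between them lies beyond the usual scatter. Among the measured compounds shown here, compound 1 and compound 2 differ in two places at once, in the length of the amide chain and in whether a fluorine is present, so their two values show only that the pair as a whole differs, not what each change contributes.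

Compound 3, `CCCNC(=O)c1cc(Oc2ccc(NC(=O)c3cc4cccnc4n(-c4ccccc4F)c3=O)cc2)ccn1`, has not yet been measured. It arises from compound 2 by a single change: fluoro in place of hydrogen on an aromatic carbon, ortho to a large group. For the measured compounds named here, no measured pair isolates this change, and the data give no basis for a direction. The step from compound 2 to compound 3 is therefore expected to be small, a 1.2-fold higher number from compound 2 to compound 3 (0.08 log units; within the scatter), not clearly beyond the scatter in either direction. Compound 3 is estimated at 1800 nM, with a range from 700 nM to 5000 nM.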

Compound 3, half-maximal inhibitory concentration: 2320 nM
Compound 3: middle estimate off by 1.3-fold (0.11 log units), on the low side; the range from low to high includes it.
By their numbers in this assay, from the lowest: compounds 2, 3 and 1 (each within the scatter of the next, the first and the last beyond it).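

In this assay, among the compounds shown here, the change from phenyl to 2-fluorophenyl is isolated for the first time, and with the longer amide chain held constant it gives a 1.5-fold higher number from compound 2 to compound 3 (0.19 log units; within the scatter), so fluoro in place of hydrogen at this carbon, ortho to a large group, does not clearly shift the number in either direction. The second single change, ethyl in place of hydrogen on a saturated chain carbon bound to an amide-type nitrogen, with the 2-fluorophenyl kept, gives a 1.4-fold lower number from compound 1 to compound 3 (0.16 log units; within the scatter), so the gap that lies beyond the scatter between compound 1 and compound 2 now resolves into two steps, neither of which is beyond the scatter on its own. Nothing on hand offers any measurement that would explain these numbers.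

The compounds shown leave open whether chloro or methoxy on that same aromatic carbon would give a step beyond the scatter, since fluoro is the only replacement for hydrogen there. They also leave open how a longer chain, or an amine or a carboxylic acid carried on the amide chain, would read in this assay on the shared core.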